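Shortening the sulfur-bound chain in a thromboxane receptor series

The compounds below may be only part of what the source reports. "The series", "measured", "known", "first", "only" and "open" are said of these compounds alone.

Among the measured compounds shown here, compound 2 `CCCCCCCCSCC1C2CCC(O2)C1C/C=C\CCCC(=O)O` stands at the highest number of the two compounds measured so far: in a functional assay on a cell-free system (plasma) for inhibition of thromboxane A2 receptor (Homo sapiens) (on this read-out higher numbers stand for weaker inhibition and lower numbers for stronger inhibition), compound 2 gives 547000 nM, while compound 1 `CCCCSCSCC1C2CCC(O2)C1C/C=C\CCCC(=O)O` gives 700 nM. For the measured compounds named here, the only step known within this small set is the exchange of butylsulfanyl for heptyl, which brought a 780-fold higher number from compound 1 to compound 2 (2.89 log units; beyond the scatter). Compound 3 `CCC/C=C\CSCC1C2CCC(O2)C1C/C=C\CCCC(=O)O` has not yet been measured; it differs from compound 2 by pent-1-en-1-yl in place of heptyl on a saturated chain carbon bound to a sulfur. Going by the values given here, that change moves the chain back toward the length seen in compound 1, which suggests that the direction of the single known step should reverse. The size of the reversal is uncertain, since the entering group carries a double bond that neither measured compound contains, so the expected step is set well short of a full return: compound 3 is expected to sit at 20000 nM in this assay, with a range from 2000 nM to 200000 nM, that is a 27-fold lower number from compound 2 to compound 3 (1.44 log units; beyond the scatter).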

Compound 3, half-maximal inhibitory concentration: 5700 nM
Compound 3: middle estimate off by 3.5-fold (0.55 log units), on the high side, and the stated range covers the measured number.
By their numbers in this assay, from the lowest: compound 1; then compound 3; then compound 2.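

In this assay, pent-1-en-1-yl in place of heptyl on a saturated chain carbon bound to a sulfur gives a 96-fold lower number from compound 2 to compound 3 (1.98 log units; beyond the scatter), which shows that a group without the second sulfur of butylsulfanyl can recover most of the ground lost with heptyl. The recovery is incomplete, with an 8.1-fold higher number from compound 1 to compound 3 (0.91 log units; beyond the scatter) still separating the two compounds, so butylsulfanyl gives the lowest number of the three groups at this position. No supporting evidence is available to explain either step.

The exchange shortens the chain and adds a double bond in one change, and a saturated pentyl group on the same carbon would be needed to tell those two apart. As far as these compounds go, how an amine or a hydroxyl group at the end of this chain would read also remains open.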